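Naphthalene in place of fluorophenyl on a uridine triphosphate

This account rests on a few compounds, and the source may have more. Where it says the series, first, only, none or still open, it means among the compounds named here.

Measured so far:
compound 1 `O=c1[nH]/c(=N\OCCCc2ccc(F)cc2)ccn1[C@@H]1O[C@H](COP(=O)(O)OP(=O)(O)OP(=O)(O)O)[C@@H](O)[C@H]1O`: 1210 nM
compound 2 `O=c1[nH]/c(=N\OCCCc2cccnc2)ccn1[C@@H]1O[C@H](COP(=O)(O)OP(=O)(O)OP(=O)(O)O)[C@@H](O)[C@H]1O`: 2950 nM
compound 3 `O=c1[nH]/c(=N\OCCCc2ccncc2)ccn1[C@@H]1O[C@H](COP(=O)(O)OP(=O)(O)OP(=O)(O)O)[C@@H](O)[C@H]1O`: 4280 nM

Three compounds share a common core and differ only in the aromatic group at the end of a three-carbon chain. In a functional assay on 1321-N1 cells for agonist activity at P2Y purinoceptor 6 (Homo sapiens), read by scintillation counting and inositol phosphate accumulation (a higher number here means that more compound is needed for the effect, a lower number that less compound is needed), compound 1 gives 1210 nM, the lowest of the three numbers. Compound 2, which carries pyridin-3-yl at that position, gives 2950 nM, and compound 3, with pyridin-4-yl, gives 4280 nM. Both steps away from compound 1 go the same way: a 2.4-fold higher number from compound 1 to compound 2 (0.39 log units; beyond the scatter) and a 3.5-fold higher number from compound 1 to compound 3 (0.55 log units; beyond the scatter). Between the two pyridyl compounds the step of a 1.5-fold higher number from compound 2 to compound 3 (0.16 log units; within the scatter) is not telling.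

Compound 4 `O=c1[nH]/c(=N\OCCCc2ccc3ccccc3c2)ccn1[C@@H]1O[C@H](COP(=O)(O)OP(=O)(O)OP(=O)(O)O)[C@@H](O)[C@H]1O` has not yet been measured. Its change from compound 1 is naphthalen-2-yl in place of 4-fluorophenyl on a saturated chain carbon, three bonds along the chain from an oxygen. The two measured steps from compound 1 concern the same position, yet both replace a carbon-only ring with a ring containing nitrogen, which is not what happens here; neither shows what a second carbon-only ring does. In this assay compound 4 is therefore expected to lie close to compound 1, with the step of a 1.1-fold lower number from compound 1 to compound 4 (0.04 log units; within the scatter) most likely within the scatter. The expected value for compound 4 is 1100 nM, with a range from 350 nM to 3500 nM.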

Compound 4, half-maximal effective concentration: 90 nM
The estimate for compound 4 lay 12-fold (1.09 log units) above the measured number; the measured number lies below the stated range.
By their numbers in this assay, from the lowest: compound 4; then compound 1; then compounds 2 and 3 (each within the scatter of the next).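

In this assay, the position on a saturated chain carbon, three bonds along the chain from an oxygen, proves far more responsive than the pyridyl compounds had suggested: naphthalen-2-yl in place of 4-fluorophenyl gives a large drop (a 13-fold lower number from compound 1 to compound 4 (1.13 log units; beyond the scatter)), and the change runs in the opposite direction to both steps from compound 1 to a ring containing nitrogen. Going by these compounds alone, measured against the pyridyl compounds, the same group gives still larger steps (a 48-fold lower number from compound 3 to compound 4 (1.68 log units; beyond the scatter); a 33-fold lower number from compound 2 to compound 4 (1.52 log units; beyond the scatter)), so compound 4 stands clearly apart from the other three and the range of numbers at this position is much wider than the earlier compounds showed. No evidence is available on why naphthalen-2-yl has this effect at this position.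

The compounds shown leave open whether the gain depends on the second ring containing only carbon, which a quinolin-3-yl group would test, and whether the point of attachment matters, which naphthalen-1-yl would test. Going by these compounds, it also remains open how naphthalen-2-yl would behave on a shorter or longer chain, or whether a biphenyl-4-yl group would give a similarly low number.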